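This account rests on a few compounds, and the source may have more. Where it says the series, first, only, none or still open, it means among the compounds named here.

In a functional assay on HeLa cells (Homo sapiens) for cytotoxicity, read by XTT assay, with a stated time of 72 h (a higher number here means a weaker inhibitor, a lower number a stronger inhibitor), compound 1 (`CCCCCCCC/C=C\CCCCCCCCOc1cc(O)cc(O)c1C(C)=O`) gives > 100000 nM as a limit, not a number. Compound 2 (`C=C1CC[C@H]2C(C)(C)CCC[C@]2(C)[C@H]1CC/C(C)=C/COc1cc(O)c2c(=O)c(OC/C=C(\C)CC[C@H]3C(=C)CC[C@H]4C(C)(C)CCC[C@]34C)c(-c3ccc(OC)cc3)oc2c1`) gives > 100000 nM as a limit too. Compound 1 therefore stands at the limit of > 100000 nM in this assay, at which 2 of the 2 values shown sit, and has no exact value. Compound 3 (`CCCCCCCCCCCCCCCCCCOc1cc(O)cc(O)c1C(C)=O`) keeps the core of compound 1 and alters only the chain: decyl in place of dec-1-en-1-yl on a saturated chain carbon, eight bonds along the chain from an oxygen on an aromatic ring with decyl in place of dec-1-en-1-yl, eight bonds along the chain from an oxygen on an aromatic ring. Within the data shown here, no measured step covers this change. The expected a number no higher from compound 1 to compound 3 (the limit leaves the size open) stays within the usual scatter, in neither direction. Compound 3 is estimated at 100000 nM (expected range 40000 nM to 200000 nM) and may well be reported only as a limit.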

Compound 3, half-maximal inhibitory concentration: > 100000 nM
Compound 3 gave a limit, no number; the forecaster's own chance of this, stated with the estimate: 75%; the middle value lies on the limit itself.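

Among these compounds, compound 1 and compound 3 each give only a limit, not a number, so no step between them can be read: the limit of > 100000 nM in this assay, at which 3 of the 3 values shown sit. Whether decyl in place of dec-1-en-1-yl changes the result at all stays open, as does where the true value of any of these compounds lies.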